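The source may hold more compounds than are shown below. What is called first, only, known or untested is meant among the compounds shown, and "the series" means these compounds.

Compound 1 `O=C(c1ccc2c(c1)OCCO2)C1CCN(Cc2coc(-c3ccc(C(F)(F)F)cc3)n2)CC1`: in an ADME assay on HEK293 cells (Homo sapiens) for cytotoxicity, read by MTT assay, with a stated time of 36 h (a lower number here means a stronger inhibitor, a higher number a weaker inhibitor), compound 1 reaches only a limit, > 150 ug/mL.
Compound 2 `CC(C)(C)c1ccc(-c2nc(CN3CCC(C(=O)c4ccc5c(c4)OCCO5)CC3)cs2)cc1`: in this assay compound 2 has "not determined" (no result reported).
Compound 3 `O=C(c1ccc(F)c(F)c1)C1CCN(Cc2coc(-c3ccc(F)cc3)n2)CC1`: in this assay compound 3 reaches only a limit, > 150 ug/mL.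

Compound 3 therefore stands at the edge of what this assay can resolve, and it is not alone there: the limit of > 150 ug/mL in this assay, at which 2 of the 3 values shown sit, while the remaining entry carries no number at all. Within the data shown here, no pair of measured compounds differs in a single place, so no measured step exists to build on.

Compound 4 `COc1ccc(C(=O)C2CCN(Cc3coc(-c4ccc(F)cc4)n3)CC2)cc1OC` differs from compound 3 in one place: 3,4-dimethoxyphenyl in place of 3,4-difluorophenyl on a carbonyl carbon. The step from compound 3 to compound 4 in this assay is expected to be a step that the limit leaves unreadable from compound 3 to compound 4, which is no change beyond the usual scatter. Compound 4 is expected to give about 200 ug/mL in this assay, with a range from 100 ug/mL to 400 ug/mL, and most probably only a limit will be reported again.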

Compound 4, half-maximal inhibitory concentration: > 150 ug/mL
Compound 4: only a limit was reported (the forecaster's own chance of this, stated with the estimate: 80%); the middle value is on the limit's open side.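

In this assay compound 4 gives only a limit, > 150 ug/mL. Among these compounds, compound 3 also gives only a limit, so no step between compound 3 and compound 4 can be read. The compounds shown leave open whether 3,4-dimethoxyphenyl and 3,4-difluorophenyl differ in this read-out at all.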